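The source may hold more compounds than are shown below. What is called first, only, known or untested is meant among the compounds shown, and "the series" means these compounds.

In an assay on CHO-K1 cells for displacement of a labelled ligand from prostaglandin E2 receptor EP1 subtype (Homo sapiens) (a lower number here means a stronger inhibitor, a higher number a weaker inhibitor), the three measured compounds gave these numbers:

Compound 1, `Cc1cc(C(N)=O)nn1Cc1cc(Cl)ccc1OCc1ccccc1`: 126 nM
Compound 2, `Cc1cc(C(=O)NC(C)C)nn1Cc1cc(Cl)ccc1OCc1ccccc1`: 126 nM
Compound 3, `CC(=O)Nc1cc(C)n(Cc2cc(Cl)ccc2OCc2ccccc2)n1`: 316 nM

Compound 3 has the highest number of the three, which makes it the weakest of these inhibitors: a 2.5-fold higher number from compound 1 to compound 3 (0.40 log units; beyond the scatter) and a 2.5-fold higher number from compound 2 to compound 3 (0.40 log units; beyond the scatter), while no change at the digits printed from compound 1 to compound 2 (within the scatter). Compound 4, `Cc1cc(NC(=O)c2c(F)cccc2F)nn1Cc1cc(Cl)ccc1OCc1ccccc1`, differs from compound 3 in one place: 2,6-difluorophenyl in place of methyl on a carbonyl carbon. Among the compounds with values here, none of the measured steps touches this part of the molecule; the two steps that lead to compound 3 swap the whole acetamido group for a carbamoyl group rather than changing what sits on the carbonyl carbon. The expectation therefore rests on little beyond the value of compound 3 itself, and the range given is wide. For compound 4 the estimated value is 200 nM (range 50 nM to 800 nM), an expected step of a 1.6-fold lower number from compound 3 to compound 4 (0.20 log units; within the scatter).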

Compound 4, half-maximal inhibitory concentration: 12.6 nM
Compound 4: middle estimate off by 16-fold (1.20 log units), on the high side; the whole stated range lies above it.
By their numbers in this assay, from the lowest: compound 4; then compounds 1 and 2 (each within the scatter of the next); then compound 3.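

The group on the carbonyl carbon matters strongly in this assay: 2,6-difluorophenyl in place of methyl gives a 25-fold lower number from compound 3 to compound 4 (1.40 log units; beyond the scatter). Compound 4 also stands clear of the two compounds carrying a carbamoyl-type group, with a 10-fold lower number from compound 1 to compound 4 (1.00 log units; beyond the scatter) and a 10-fold lower number from compound 2 to compound 4 (1.00 log units; beyond the scatter). Nothing available explains this gain.

The compounds shown leave open whether the gain needs the ring, the fluorines or both. A plain phenyl, a 2-fluorophenyl or a cyclohexyl on the same carbonyl carbon would help separate these.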